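The source may hold more compounds than are shown below. What is called first, only, known or untested is meant among the compounds shown, and "the series" means these compounds.

Measured in an ADME assay on L02 cells (Homo sapiens) for cytotoxicity, read by MTT assay, with a stated time of 72 h; on this read-out higher numbers stand for weaker inhibition and lower numbers for stronger inhibition:
compound 1 `O=C(CCC(=O)OCCCCCCSc1ccc([N+](=O)[O-])c2nonc12)Nc1ccccc1` gives 6490 nM
compound 2 `COc1ccccc1NC(=O)CCC(=O)OCCCCCCSc1ccc([N+](=O)[O-])c2nonc12` gives 4490 nM
compound 3 `Cc1ccc(NC(=O)CCC(=O)OCCCCCCSc2ccc([N+](=O)[O-])c3nonc23)cc1` gives 7320 nM

Compound 2 has the lowest number of the three, yet its gaps to the others stay within the scatter: a 1.4-fold lower number from compound 1 to compound 2 (0.16 log units; within the scatter) and a 1.6-fold higher number from compound 2 to compound 3 (0.21 log units; within the scatter); likewise a 1.1-fold higher number from compound 1 to compound 3 (0.05 log units; within the scatter). Compound 4 `CN(C)CCNC(=O)CCC(=O)OCCCCCCSc1ccc([N+](=O)[O-])c2nonc12` differs from compound 2 by 2-(dimethylamino)ethyl in place of 2-methoxyphenyl on an amide-type nitrogen. Every measured step only exchanges one small group on the aromatic ring held by the amide-type nitrogen, or swaps one such ring for another, and none moved the number in this assay beyond the scatter. Among the compounds with values here, no measured step removes that ring, so none bears directly on this change. With all observed steps flat, no shift beyond the scatter is expected, but the range is set wide. Compound 4 is therefore estimated at 6000 nM, between 2500 nM and 15000 nM, an expected step of a 1.3-fold higher number from compound 2 to compound 4 (0.13 log units; within the scatter).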

Compound 4, half-maximal inhibitory concentration: 5980 nM
For compound 4 the middle estimate is 1.0-fold (0.00 log units) above the measured one, within the range that was stated.
By their numbers in this assay, from the lowest: compounds 2, 4, 1 and 3 (each within the scatter of the next).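

In this assay the aromatic ring on the amide-type nitrogen is not needed to keep the number within the scatter: an open-chain 2-(dimethylamino)ethyl takes its place without a step beyond it (a 1.3-fold higher number from compound 2 to compound 4 (0.12 log units; within the scatter) and a 1.2-fold lower number from compound 3 to compound 4 (0.09 log units; within the scatter) and a 1.1-fold lower number from compound 1 to compound 4 (0.04 log units; within the scatter)). Across these four compounds, neither the ring nor the substituents on it separate the values at this position. No measurement here accounts for this flatness.

On these data alone, whether a carboxylic acid, a primary amine or a longer chain on this nitrogen would also stay within the scatter remains open. So does whether any group at this position can move the number at all.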